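Shrinking the Amine Ring on Two Related Cores

This account rests on a few compounds, and the source may have more. Where it says the series, first, only, none or still open, it means among the compounds named here.

Compound 1 `COc1cc2c(Oc3ccc(NC(=O)c4cc(-c5ccc(Cl)c(Cl)c5)nc5ccccc45)cc3F)ccnc2cc1OCCCN1CCCCC1` and compound 2 `COc1cc2c(Oc3ccc(NC(=O)c4cc(-c5ccc(Cl)c(Cl)c5)nc5ccccc45)cc3F)ccnc2cc1OCCCN1CCCC1` share one core, while compound 3 `COc1cc2c(Oc3ccc(NC(=O)c4cc(-c5ccccc5)nc5ccc(F)cc45)cc3F)ccnc2cc1OCCCN1CCCCC1` and compound 4 `COc1cc2c(Oc3ccc(NC(=O)c4cc(-c5ccccc5)nc5ccc(F)cc45)cc3F)ccnc2cc1OCCCN1CCCC1` share another; the difference between the two cores is not broken down here. In a functional assay on MKN-45 cells (Homo sapiens) for cytotoxicity, read by MTT assay, with a stated time of 72 h (on this read-out lower numbers stand for stronger inhibition and higher numbers for weaker inhibition), compound 1 gives 730 nM. Compound 2 gives 170 nM in this assay. The change from compound 1 to compound 2 is pyrrolidin-1-yl in place of piperidin-1-yl on a saturated chain carbon, three bonds along the chain from an oxygen on an aromatic ring, and it produced a step of a 4.3-fold lower number from compound 1 to compound 2 (0.63 log units; beyond the scatter). Compound 3 gives 30 nM in this assay, the lowest number of the three measured compounds, with both others beyond the usual scatter from it. Compound 4 carries the same change relative to compound 3, namely (pyrrolidin-1-yl in place of piperidin-1-yl on a saturated chain carbon, three bonds along the chain from an oxygen on an aromatic ring), placed word for word as before, so it is the same change set on a different core. Among the compounds with values here, whether a change repeats its effect on another core cannot be known from one pair alone, yet that single pair is the only guide available. The expected step is a 3.0-fold lower number from compound 3 to compound 4 (0.48 log units; beyond the scatter), somewhat smaller than the earlier one, because a 4.3-fold lower number from compound 1 to compound 2 (0.63 log units; beyond the scatter) rests on a single example and repeated measurements of this kind scatter. Compound 4 is therefore estimated at 10 nM, with a likely range from 4 nM to 30 nM.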

Compound 4, half-maximal inhibitory concentration: 110 nM
For compound 4 the middle estimate is 11-fold (1.04 log units) below the measured one; measured number above the stated range.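

In this assay, putting pyrrolidin-1-yl in place of piperidin-1-yl on the second core gave a 3.7-fold higher number from compound 3 to compound 4 (0.56 log units; beyond the scatter), so the smaller amine ring that lowered the number on the first core raised it here. Set side by side, the two results run in opposite directions, and the gap between them is too large to dismiss as ordinary variation between repeated measurements: the same change on two cores in this assay, a 4.3-fold lower number (0.63 log units; beyond the scatter) from compound 1 to compound 2 and a 3.7-fold higher number (0.56 log units; beyond the scatter) from compound 3 to compound 4, 16-fold (1.20 log units) apart, beyond the scatter of two such steps

Within the data shown here, this shows that the effect of the ring change on one core does not predict even the direction of its effect on the other, so a step measured on one core cannot simply be carried over to the other; it does not show which difference between the cores reverses the effect, and with only two pairs it supports no general rule for either ring.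

The compounds shown leave open which part of the difference between the two cores governs the direction of the step, since no compound here separates the two chlorines from the fluorine. They also leave open how other amines, such as morpholine or dimethylamine, or a shorter chain such as 2-(pyrrolidin-1-yl)ethyl, would behave on each core.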